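Toward compound 4: replacing the amino acid arm of compound 3

This account rests on a few compounds, and the source may have more. Where it says the series, first, only, none or still open, it means among the compounds named here.

Compound 3 `CCCCCCCCCCc1ccc(-c2noc(CC[C@@H](N)C(=O)O)n2)cc1` gives 5% in an assay on HeLa cells for inhibition of sphingosine-1-phosphate transporter SPNS2 (Mus musculus), read by LC-MS, tested at 2 uM (a higher number here means more inhibition at the concentration tested (going by the name of the read-out), a lower number less inhibition), and stands lowest of the three measured compounds. Compound 1 `CCCCCCCCCCc1ccc(-c2noc([C@@H]3CCNC3)n2)cc1` gives 62% and compound 2 `CCCCCCCCCCc1ccc(-c2noc([C@@H]3CC[C@H](N)C3)n2)cc1` gives 38%; the steps of a number 57 percentage points lower from compound 1 to compound 3 (beyond the scatter) and a number 33 percentage points lower from compound 2 to compound 3 (beyond the scatter) both run downward toward compound 3. Compound 4 `CCCCCCCCCCc1ccc(-c2noc(CC(O)CNCC)n2)cc1` differs from compound 3 by 2-(ethylamino)-1-hydroxyethyl in place of 2-amino-2-carboxyethyl on a saturated chain carbon bound to an aromatic carbon. For the measured compounds named here, no measured step covers this exact change, but the 2-amino-2-carboxyethyl group that leaves marks the compound with the lowest number, while compounds 1 and 2, which carry an amine without a carboxy group, both give higher numbers in this assay. Compound 4 is therefore expected to move upward, a number 30 percentage points higher from compound 3 to compound 4 (beyond the scatter), and its inhibition is estimated at 35% with a range from 10% to 65%.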

Compound 4, a percentage reported as inhibition, at one concentration (the size of the read-out at that concentration, not a potency): 5%
Estimate against measurement, compound 4: 30 percentage points above; measured number outside the range, below it.
By their numbers in this assay, from the lowest: compounds 3 and 4 (each within the scatter of the next); then compound 2; then compound 1.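

In this assay, the exchange of 2-amino-2-carboxyethyl for 2-(ethylamino)-1-hydroxyethyl gives no change at the digits printed from compound 3 to compound 4 (within the scatter), so removing the carboxy group at this position does not by itself raise the number. Against the ring-bearing amines the open chain gives a number 33 percentage points lower from compound 2 to compound 4 (beyond the scatter) and a number 57 percentage points lower from compound 1 to compound 4 (beyond the scatter), which shows that an amine without a carboxy group is not enough here. No measurement shown explains this result.

On these data alone, it remains open whether the hydroxy group, the ethyl group on the nitrogen or the open chain itself holds the number down. A plain 3-aminopropyl chain or a piperidin-3-yl ring could separate these possibilities.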